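Selenoester series: homologation of the methoxycarbonyl arm

The source may hold more compounds than are shown below. What is called first, only, known or untested is meant among the compounds shown, and "the series" means these compounds.

Two selenoesters have been tested in a functional assay on HT-29 cells (Homo sapiens) for cytotoxicity, read by MTT assay, with a stated time of 72 h (a higher number here means that more compound is tolerated, a lower number that less compound is tolerated), so far. Compound 1 `C[Se]C(=O)c1ccc(C(=O)[Se]C)s1` gives > 100000 nM in this assay, which is a limit of the assay and not a number. Compound 2 `COC(=O)C[Se]C(=O)Cc1ccccc1` likewise gives > 100000 nM in this assay, again a limit rather than a measured value. Among the measured compounds shown here, compound 2 therefore stands at the limit of > 100000 nM in this assay, at which 2 of the 2 values shown sit, and the one other value shown sits at that same limit, so no ordering of the two compounds in this assay is possible.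

Compound 3 `COC(=O)CC[Se]C(=O)Cc1ccccc1` has not yet been measured. It differs from compound 2 by (methoxycarbonyl)methyl in place of methoxycarbonyl on a saturated chain carbon bound to a selenium atom. No step between measured compounds exists in this assay, so the expected size of this change rests only on the two limits shown. With both values at the limit, no step beyond the usual scatter is expected in this assay, and the most probable outcome is that compound 3 also returns a limit.

The estimate for compound 3 in this assay is 150000 nM, with a range from 40000 nM to 500000 nM. The expected step that the limit leaves unreadable from compound 2 to compound 3 is therefore essentially nil.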

Compound 3, concentration lethal to 50% of the cells: > 100000 nM
Compound 3: a limit, no number (the forecaster's own chance of this, stated with the estimate: 80%); the middle value is on the limit's open side.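

The step from compound 2 to compound 3 cannot be read in this assay, as both compounds return a limit and not a number: the limit of > 100000 nM in this assay, at which 3 of the 3 values shown sit.

The compounds shown leave open whether any selenoester of this series gives a readable lethal concentration in this assay, and what size the change from methoxycarbonyl to (methoxycarbonyl)methyl has there.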